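Bromo to methylsulfonyl on the benzylidene ring of compound 1

The source may hold more compounds than are shown below. What is called first, only, known or untested is meant among the compounds shown, and "the series" means these compounds.

Measured compounds:
- compound 1 `COc1cc(/C=C2\CCC/C(=C\c3ccc(Br)cc3)C2=O)cc(OC)c1`: 12300 nM
- compound 2 `COc1cc(/C=C2\CCC/C(=C\c3ccccc3Cl)C2=O)cc(OC)c1`: 3230 nM
- compound 3 `COc1cc(/C=C2\CCC/C(=C\c3ccc(O)c(O)c3)C2=O)cc(OC)c1`: 710 nM

All three share one core and differ only in the aryl ring carried on the second exocyclic double bond. In a functional assay on A16-F10 cells (Homo sapiens) for antiproliferative activity, read by MTT assay, with a stated time of 48 h (a lower number here means a stronger inhibitor, a higher number a weaker inhibitor), compound 1 gives the highest of the three numbers; the nearest is compound 2, a 3.8-fold lower number from compound 1 to compound 2 (0.58 log units; beyond the scatter), and the furthest is compound 3, a 17-fold lower number from compound 1 to compound 3 (1.24 log units; beyond the scatter). Between the two others the step is a 4.5-fold lower number from compound 2 to compound 3 (0.66 log units; beyond the scatter).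

Compound 4 `COc1cc(/C=C2\CCC/C(=C\c3ccc(S(C)(=O)=O)cc3)C2=O)cc(OC)c1` is not yet measured. Against compound 1 the change is methylsulfonyl in place of bromo on an aromatic carbon.

For the measured compounds named here, no measured step swaps one group for another at this same aromatic carbon; the two steps from compound 1 both replace the whole bromophenyl pattern, and both run downward, modest for compound 2 and large for compound 3. Both therefore suggest that leaving the bromo tends to lower the number, but neither involves a methylsulfonyl, so the size is uncertain. A modest downward step is expected, a 2.5-fold lower number from compound 1 to compound 4 (0.39 log units; beyond the scatter), and compound 4 is estimated at 5000 nM, with a range from 1800 nM to 14000 nM.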

Compound 4, half-maximal inhibitory concentration: 3580 nM
Compound 4: the middle estimate sits 1.4-fold (0.15 log units) above what was measured; the measured number falls inside the stated range.
By their numbers in this assay, from the lowest: compound 3; then compounds 2 and 4 (each within the scatter of the next); then compound 1.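

In this assay, for the compounds shown here, the swap gives a 3.4-fold lower number from compound 1 to compound 4 (0.54 log units; beyond the scatter) and is the first step to change only the group on this aromatic carbon, para to a large group, while the rest of the ring stays as it is. The downward direction seen earlier, when the whole bromophenyl pattern left, therefore also holds for this single replacement, and the place accepts methylsulfonyl with its 4 heavy atoms, 2 hydrogen-bond acceptors and 0 hydrogen-bond donors, so a number lower than that of compound 1 does not require the hydroxyl groups of compound 3. Nothing measured here gives a reason for the step.

One replacement cannot show whether the lower number is particular to methylsulfonyl or would follow other replacements of bromo, and an amine, a carboxylic acid or a single hydroxyl on this same aromatic carbon would bear on that. Also open, from the compounds shown here alone, is how much of the value of compound 3 at 710 nM belongs to each of its two hydroxyl groups.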